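The compounds below may be only part of what the source reports. "The series", "measured", "known", "first", "only" and "open" are said of these compounds alone.

Measured compounds in a physicochemical assay for solubility; a higher number here means a more soluble compound, a lower number a less soluble compound:
compound 1 `N#CCn1c(=O)n(-c2ccc(C#N)c(C(F)(F)F)c2)c2ccccc21` gives 18900 nM
compound 2 `Cc1ccc(-n2c(=O)n(-c3ccc(C#N)c(C(F)(F)F)c3)c3ccccc32)cc1` gives 790 nM
compound 3 `N#Cc1ccc(-n2c(=O)n(Cc3cccnc3)c3ccccc32)cc1C(F)(F)F` gives 2500 nM

Compound 3 stands second highest of the three numbers in this assay: compound 2 sits a 3.2-fold higher number from compound 2 to compound 3 (0.50 log units; beyond the scatter) on the low side of it, and compound 1 sits a 7.6-fold lower number from compound 1 to compound 3 (0.88 log units; beyond the scatter) on the high side.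

Compound 4 `CNC(=O)c1ccc(-n2c(=O)n(-c3ccc(C#N)c(C(F)(F)F)c3)c3ccccc32)cc1F` has not yet been measured. It differs from compound 3 in one place: 3-fluoro-4-(methylcarbamoyl)phenyl in place of (pyridin-3-yl)methyl on an aromatic nitrogen. The change thus exchanges a small ring-bearing chain on the shared core for a larger, six-membered aromatic ring carrying a fluorine and a methylcarbamoyl group.

Among the compounds with values here, two measured steps bear on this. The step of a 3.2-fold higher number from compound 2 to compound 3 (0.50 log units; beyond the scatter) shows that replacing an aromatic ring on that nitrogen by the (pyridin-3-yl)methyl chain gave a modestly higher number, so going back to an aromatic ring at the same place is expected to turn that step around. The step of a 24-fold lower number from compound 1 to compound 2 (1.38 log units; beyond the scatter) shows a large fall when an aromatic ring entered in place of a small chain. For compound 4 a modest fall is therefore expected, a 2.1-fold lower number from compound 3 to compound 4 (0.32 log units; beyond the scatter), though the hydrogen-bond donor that enters is not represented among the measured compounds, which widens the uncertainty. The expected value for compound 4 is 1200 nM, within a range from 400 nM to 4000 nM.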

Compound 4, solubility: 8810 nM
Compound 4: the middle estimate sits 7.3-fold (0.87 log units) below what was measured; the measured number lies above the stated range.
By their numbers in this assay, from the lowest: compound 2; then compound 3; then compound 4; then compound 1.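

In this assay, an aromatic ring on this aromatic nitrogen does not by itself bring a low number: with 3-fluoro-4-(methylcarbamoyl)phenyl in place of 4-methylphenyl, the result is a large rise (an 11-fold higher number from compound 2 to compound 4 (1.05 log units; beyond the scatter)). Within the data shown here, the same group also outranks the non-aromatic (pyridin-3-yl)methyl chain (a 3.5-fold higher number from compound 3 to compound 4 (0.55 log units; beyond the scatter)) and comes within a modest step of the small cyanomethyl group (a 2.1-fold lower number from compound 1 to compound 4 (0.33 log units; beyond the scatter)), so at this position, what the aromatic ring carries matters, and the simple contrast of ring against chain suggested by the earlier compounds no longer holds. No measured information is available here to explain why these numbers differ.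

The fluorine and the methylcarbamoyl group enter together, so the compounds shown cannot separate what each contributes to the rise from compound 2. Going by these compounds, it also remains open whether the number would stay this high with a carboxylic acid or a dimethylcarbamoyl group in place of the methylcarbamoyl group on the same ring.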